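A Vinyl-to-Ethynyl Change Tested on the Pyrimidine Ring

The source may report more compounds than this note shows. Statements on the series, on what has been measured and on what is new or still open speak of the compounds shown alone.

Of the compounds shown here, three sharing the same core have been measured in an assay on Sf9 cells for inhibition of mitogen-activated protein kinase kinase kinase 14 variant S549D (Homo sapiens), with a stated time of 30 min, in the presence of a further agent that is not named here; a lower number here means a stronger inhibitor, a higher number a weaker inhibitor. Compound 1, with the structure `C=Cc1ccnc(C#Cc2ccc3ncn(-c4ccnc(N)n4)c3c2)c1`, gives 1580 nM. Compound 2, with the structure `C#Cc1ccnc(C#Cc2ccc3ncn(-c4ccnc(N)n4)c3c2)c1`, gives 316 nM. Compound 3, with the structure `C=Cc1ccnc(C#Cc2ccc3ncn(-c4ccnc(N)n4)c3c2)n1`, gives 1580 nM. Compound 3 therefore stands level with compound 1, and together these two give the highest numbers of the three, with compound 2 the furthest from them.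

Two steps describe how the structures relate. From compound 1 to compound 2 the vinyl group was exchanged for an ethynyl group, and the result was a 5.0-fold lower number from compound 1 to compound 2 (0.70 log units; beyond the scatter). From compound 1 to compound 3 the ring carrying the vinyl group was exchanged, and the result was no change at the digits printed from compound 1 to compound 3 (within the scatter).

Compound 4, with the structure `C#Cc1cc(C#Cc2ccc3ncn(-c4ccnc(N)n4)c3c2)ncn1`, is not yet measured. It differs from compound 3 by a group of 8 heavy atoms (6 carbon, 2 nitrogen; one six-membered aromatic ring with 2 hetero atoms) in place of a group of 8 heavy atoms (6 carbon, 2 nitrogen; one six-membered aromatic ring with 2 hetero atoms), on a triple-bonded carbon. This is the same vinyl-to-ethynyl exchange seen between compound 1 and compound 2, now carried out on the ring of compound 3. Because the step of a 5.0-fold lower number from compound 1 to compound 2 (0.70 log units; beyond the scatter) was modest but clear, and because the ring exchange itself gave no change at the digits printed from compound 1 to compound 3 (within the scatter), a similar lowering is expected here.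

The expected step is a 4.9-fold lower number from compound 3 to compound 4 (0.69 log units; beyond the scatter). Compound 4 is estimated at 320 nM, with a likely range from 130 nM to 800 nM.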

Compound 4, half-maximal inhibitory concentration: 50100 nM
Compound 4: the middle estimate sits 160-fold (2.19 log units) below what was measured, outside the stated range (above it).
By their numbers in this assay, from the lowest: compound 2; then compounds 1 and 3 (each within the scatter of the next); then compound 4.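

In this assay, going by these compounds alone, the ring proves far less forgiving than the earlier compounds suggested: with the ethynyl group kept, exchanging the ring gives a 160-fold higher number from compound 2 to compound 4 (2.20 log units; beyond the scatter), although the earlier ring exchange on the vinyl compounds left the number unchanged at the digits printed. The vinyl-to-ethynyl lowering also does not carry over, for the result is a 32-fold higher number from compound 3 to compound 4 (1.50 log units; beyond the scatter), and the two structures show that the ring nitrogens are placed differently in compound 3 and compound 4, so this step is more than a double bond becoming a triple bond; the comparison with the other vinyl compound gives a similar gap, a 32-fold higher number from compound 1 to compound 4 (1.50 log units; beyond the scatter), where the ring and the group on it both differ. No measurement at hand offers an explanation for this weakening.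

Going by these compounds, whether the rise belongs to the ring alone or to the ethynyl group on that particular ring remains open. Also open, on these data alone, is how the same ring would respond to an amine or a methyl group in place of ethynyl.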